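A Spirocyclic Amide in Place of the Fluorophenyl Amide

This account rests on a few compounds, and the source may have more. Where it says the series, first, only, none or still open, it means among the compounds named here.

compound 1 `CC1CCCCC1C(=O)N1CC(c2nc(-c3cccc(F)c3)no2)C1` — > 10000 nM
compound 2 `O=C(c1ccc(F)cc1)N1CC(c2nc(-c3cccc(Cl)c3)no2)C1` — 4000 nM
compound 3 `O=C(C1CCC(C(F)(F)F)CC1)N1CC(c2nc(-c3cccc(Cl)c3)no2)C1` — > 10000 nM

Among the measured compounds shown here, in an assay on HEK293 cells for negative allosteric modulation of metabotropic glutamate receptor 5 (Homo sapiens), read by FLIPR (a lower number here means a stronger inhibitor, a higher number a weaker inhibitor), compound 2 gives 4000 nM, the only measured number among the three compounds. The value for compound 1 is a limit of the assay, not a number. The value for compound 3 is likewise a limit. For the measured compounds named here, two of the three results therefore sit at the limit of > 10000 nM in this assay, at which 2 of the 3 values shown sit, and compound 2 stands alone as the one compound with a quantified result.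

Compound 4 `O=C(C1CCC2(CCC2)CC1)N1CC(c2nc(-c3cccc(Cl)c3)no2)C1` differs from compound 2 by a group of 9 heavy atoms (9 carbon; one four-membered non-aromatic ring of carbon only, one six-membered non-aromatic ring of carbon only) in place of a group of 7 heavy atoms (6 carbon, 1 fluorine; one six-membered aromatic ring of carbon only), on a carbonyl carbon. Going by the values given here, no step between measured compounds is available to calibrate this change. Compound 4 thereby joins compound 1 and compound 3 in lacking an aromatic ring at the carbonyl carbon, and both of those compounds reached only a limit.

Compound 4 is therefore expected to be weaker than compound 2 in this assay, with the step of a 2.5-fold higher number from compound 2 to compound 4 (0.40 log units; beyond the scatter) expected to be beyond the scatter, and an estimated 10000 nM within 3000 nM to 30000 nM, with a substantial chance that only a limit is reported.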

Compound 4, half-maximal inhibitory concentration: > 10000 nM
Compound 4 was reported as a limit; the forecaster's own chance of this, stated with the estimate: 55%; the middle value sits exactly at the limit.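

In this assay compound 4 gives > 10000 nM, which is a limit of the assay and not a number. Placing the two-ring all-carbon group on the carbonyl carbon in place of 4-fluorophenyl gives an at least 2.5-fold higher number from compound 2 to compound 4 (0.39 log units; beyond the scatter), the first step at this position that can be read, though only as a lower bound. Compound 3 and compound 4 differ only in the non-aromatic group on this carbon, and neither gives a number, so two different such groups now end at the same limit: the limit of > 10000 nM in this assay, at which 3 of the 4 values shown sit.

Going by these compounds, how far compound 4 lies past the limit stays open, and the steps between limit values cannot be read. Also open, on these data alone, is whether a pyridine ring, or a phenyl ring carrying a methoxy group or a nitrile, on the carbonyl carbon would give a lower number than the 4-fluorophenyl of compound 2.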